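Notes on the amide aryl group, compounds 1 to 4

The source may report more compounds than this note shows. Statements on the series, on what has been measured and on what is new or still open speak of the compounds shown alone.

Measured so far in a functional assay on A549 cells (Homo sapiens) for antiproliferative activity, read by MTT assay, with a stated time of 72 h; on this read-out lower numbers stand for stronger inhibition and higher numbers for weaker inhibition:
compound 1 `COc1ccc(C(=O)Nc2cc(Nc3nccc(-c4cn(C)c5ccccc45)n3)c(OC)cc2F)nc1`: 8200 nM
compound 2 `COc1cc(F)c(NC(=O)c2cnccn2)cc1Nc1nccc(-c2cn(C)c3ccccc23)n1`: 2490 nM
compound 3 `COc1cc(N(C)CCN(C)C)c(NC(=O)c2ccnc(Cl)c2)cc1Nc1nccc(-c2cn(C)c3ccccc23)n1`: 970 nM

Compound 3 gives the lowest number of the three in this assay; the nearest is compound 2, and compound 1 lies furthest, both gaps beyond the scatter. Compound 4 `COc1cc(N(C)CCN(C)C)c(NC(=O)c2ncccn2)cc1Nc1nccc(-c2cn(C)c3ccccc23)n1` has not yet been measured. It differs from compound 3 in one place: pyrimidin-2-yl in place of 2-chloropyridin-4-yl on a carbonyl carbon.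

Among the measured compounds shown here, only one measured step touches the same place, the aryl group on the carbonyl carbon: a 3.3-fold lower number from compound 1 to compound 2 (0.52 log units; beyond the scatter), where one azine replaced a substituted pyridine and the number fell modestly. The change from compound 3 to compound 4 is of the same kind, a substituted pyridine giving way to a diazine, but not the same pair of groups, and compound 3 also carries a different amine side chain from compounds 1 and 2. For the measured compounds named here, the one step therefore supports at most a modest lowering and does not rule out no change beyond the scatter.

For compound 4 the expected step in this assay is a 1.4-fold lower number from compound 3 to compound 4 (0.14 log units; within the scatter). Compound 4 is thus estimated at 700 nM, with a range from 250 nM to 2000 nM.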

Compound 4, half-maximal inhibitory concentration: 2490 nM
For compound 4 the middle estimate is 3.6-fold (0.55 log units) below the measured one, outside the stated range (above it).
By their numbers in this assay, from the lowest: compound 3; then compounds 2 and 4 (each within the scatter of the next); then compound 1.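

On the carbonyl carbon of the amide, pyrimidin-2-yl in place of 2-chloropyridin-4-yl gives in this assay a 2.6-fold higher number from compound 3 to compound 4 (0.41 log units; beyond the scatter) and so shows that a diazine entering at this position does not necessarily lower the number. The earlier exchange of 5-methoxypyridin-2-yl for pyrazin-2-yl gave a 3.3-fold lower number from compound 1 to compound 2 (0.52 log units; beyond the scatter) in the opposite direction, so no single direction holds for a substituted pyridine giving way to a diazine here, and those two steps also differ in the groups exchanged and in the rest of the molecule. No measurement at hand accounts for the rise.

The step from compound 3 to compound 4 removes the chlorine and alters the ring at once, so the contribution of each stays unresolved; a plain pyridin-4-yl or a 2-methoxypyridin-4-yl on the same carbonyl carbon would separate the two. Also open, on these data alone, is whether pyrimidin-2-yl and 2-chloropyridin-4-yl keep the same order when the fluorine of compounds 1 and 2 stands in place of the amine side chain.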